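Compound 2 to compound 3: a new group on sulfonyl sulfur

The source may hold more compounds than are shown below. What is called first, only, known or untested is meant among the compounds shown, and "the series" means these compounds.

In an ADME assay on HepG2 2.2.15 cells (Homo sapiens) for cytotoxicity, read by luminescence, with a stated time of 3 days (on this read-out lower numbers stand for higher toxicity in this test and higher numbers for lower toxicity in this test), compound 1 `COC1COCCN(S(=O)(=O)c2cc(C(=O)Nc3ccc(F)c(Cl)c3)ccc2F)C1` gives 8700 nM. Compound 2 `CN1CCCN(S(=O)(=O)c2cc(C(=O)Nc3ccc(F)c(Cl)c3)ccc2F)CC1=O` gives > 100000 nM, which is a limit of the assay and not a number. Its standing is therefore known only from the limit of > 100000 nM in this assay, at which 1 of the 2 values shown sits.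

Compound 3 `CC1(O)CCCN(S(=O)(=O)c2cc(C(=O)Nc3ccc(F)c(Cl)c3)ccc2F)CC1` has not yet been measured in this assay. Its difference from compound 2 is 4-hydroxy-4-methylazepan-1-yl in place of 4-methyl-3-oxo-1,4-diazepan-1-yl on a sulfonyl sulfur.

Going by the values given here, only one measured step bears on this change: an at least 11-fold higher number from compound 1 to compound 2 (1.06 log units; beyond the scatter). It is large and lies beyond the scatter, and it involves a change of group at the same place. It shows that this place can move the read-out widely, but the entering group appears in neither measured compound. With a limit as the starting point, a measurable move can only be toward a lower number, so a step of moderate size in that direction is expected. The expected step is an at least 2.8-fold lower number from compound 2 to compound 3 (0.45 log units; beyond the scatter), and a further reading at the limit remains possible. Compound 3 is estimated at 35000 nM, with an expected range of 9000 nM to 100000 nM.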

Compound 3, half-maximal cytotoxic concentration: 11000 nM
The estimate for compound 3 lay 3.2-fold (0.50 log units) above the measured number, and the stated range covers the measured number.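

In this assay, replacing 4-methyl-3-oxo-1,4-diazepan-1-yl with 4-hydroxy-4-methylazepan-1-yl on the sulfonyl sulfur gives an at least 9.0-fold lower number from compound 2 to compound 3 (0.95 log units; beyond the scatter), so the high reading is not shared by every group tried at this place. The second comparison reads a 1.3-fold higher number from compound 1 to compound 3 (0.10 log units; within the scatter), which leaves 4-hydroxy-4-methylazepan-1-yl and 6-methoxy-1,4-oxazepan-4-yl without a distinction here; of the three groups, only 4-methyl-3-oxo-1,4-diazepan-1-yl stands apart. The value of compound 2 is a limit of the assay and not a number, so its gap to the other two compounds is bounded on one side only: the limit of > 100000 nM in this assay, at which 1 of the 3 values shown sits.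

Whether the high reading of compound 2 goes with the ring carbonyl, the second ring nitrogen, its methyl group or their combination stays open, as these features change together in the compounds shown. Also open, as far as these compounds go, is how the read-out responds when an amine or a carboxylic acid takes the place of the hydroxy group in 4-hydroxy-4-methylazepan-1-yl, which would test whether values near those of compound 1 and compound 3 hold for groups of other kinds.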